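This account rests on a few compounds, and the source may have more. Where it says the series, first, only, none or still open, it means among the compounds named here.

Compound 1 `C[C@H](NC(=O)c1cnnn1Cc1ccc(C(F)(F)F)cc1)c1ccc(C(=O)O)cc1`: > 10000 nM
Compound 2 `COc1ccc(Cn2nnc(-c3ccccc3)c2C(=O)N[C@@H](C)c2ccc(C(=O)O)cc2)cc1`: 9.3 nM
Compound 3 `C[C@H](NC(=O)c1c(-c2ccccc2)nnn1CCOc1ccc(F)cc1)c1ccc(C(=O)O)cc1`: 3.1 nM

All three were tested in a functional assay on CHO cells for antagonist activity at prostaglandin E2 receptor EP4 subtype (Homo sapiens), read by calcium flux, with a stated time of 15 min; on this read-out higher numbers stand for weaker inhibition and lower numbers for stronger inhibition. Within the data shown here, for compound 1 the result is only a limit of the assay, > 10000 nM, and it is the one value that sits at the limit of > 10000 nM in this assay, at which 1 of the 3 values shown sits. Compound 2 gives 9.3 nM in this assay, and compound 3 gives 3.1 nM. Among the measured compounds shown here, the single measured step, a 3.0-fold lower number from compound 2 to compound 3 (0.48 log units; beyond the scatter), concerns the group on the saturated chain carbon bound to the aromatic nitrogen and leaves the rest of the shared core untouched.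

Compound 4 `C[C@H](NC(=O)c1c(C2=CCCCC2)nnn1Cc1ccc(C(F)(F)F)cc1)c1ccc(C(=O)O)cc1` differs from compound 1 in one place: cyclohex-1-en-1-yl in place of hydrogen on an aromatic carbon. For the measured compounds named here, no measured step alters that aromatic carbon, so the step from compound 2 to compound 3 is at best an indirect guide. What the numbers do show is that compounds 2 and 3, which both carry a group rather than hydrogen on that ring carbon, give numbers far from the limit reported for compound 1. On that basis compound 4 is expected to give a much lower number than compound 1, an estimated step of an at least 330-fold lower number from compound 1 to compound 4 (2.52 log units; beyond the scatter). The estimate for compound 4 in this assay is 30 nM, with a range from 5 nM to 400 nM.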

Compound 4, half-maximal inhibitory concentration: 183 nM
Compound 4: the middle estimate sits 6.1-fold (0.79 log units) below what was measured; the range from low to high includes it.
By their numbers in this assay, from the lowest: compound 3; then compound 2; then compound 4. At a limit, above all of these: compound 1.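

Cyclohex-1-en-1-yl in place of hydrogen on this aromatic carbon brings an at least 54-fold lower number from compound 1 to compound 4 (1.73 log units; beyond the scatter) in this assay, a direct step showing that what sits here matters while the 4-(trifluoromethyl)benzyl group stays unchanged. On these data alone, the true size of that step remains unknown, because the value for compound 1 is only a limit: the limit of > 10000 nM in this assay, at which 1 of the 4 values shown sits. The entering group is built of carbon only, with 0 hydrogen-bond donors and 0 hydrogen-bond acceptors, so a group of this kind is enough to bring a measurable number.

As far as these compounds go, whether a methyl group, a saturated cyclohexyl ring or an amine on this carbon would do the same remains open. From the compounds shown here alone, compound 4 differs from compound 2 and compound 3 in more than one place, so how cyclohex-1-en-1-yl compares with phenyl here also remains open.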